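Extending the Alkenyl Chain of Compound 3

A few compounds are considered here, and "the series" means these few. Any claim that something is new, unique, unknown or untested is made for them only; others in the source may bear on it.

Compound 3 `CC/C=C/C(=O)Nc1cccc(Oc2nc(Nc3cccc(C#N)c3)nc3ccsc23)c1` gives > 50000 nM in an ADME assay on L02 cells (Homo sapiens) for inhibition, read by MTT assay, with a stated time of 72 h (on this read-out lower numbers stand for stronger inhibition and higher numbers for weaker inhibition), which is a limit of the assay rather than a number. Compound 1 `CCC/C=C/C(=O)Nc1cccc(Oc2nc(Nc3cccc(OC)c3)nc3ccsc23)c1` likewise gives > 50000 nM, also a limit. Compound 2 `C=CC(=O)Nc1cccc(Oc2nc(Nc3cccc(C#N)c3)nc3ccsc23)c1` gives > 50000 nM, again a limit. All three values sit at the limit of > 50000 nM in this assay, at which 3 of the 3 values shown sit, so the step that the two limits leave unreadable from compound 2 to compound 3 cannot be read in size. Compound 4 `CCC/C=C/C(=O)Nc1cccc(Oc2nc(Nc3cccc(C#N)c3)nc3ccsc23)c1` differs from compound 3 by methyl in place of hydrogen on a saturated chain carbon, two bonds along the chain from a double-bonded chain carbon. With no readable step in this assay, no change beyond the scatter is expected from this addition, and the limit seen for compound 3 is expected to persist. Compound 4 is therefore estimated at 80000 nM, ranging from 40000 nM to 200000 nM. This estimate means a step that the limit leaves unreadable from compound 3 to compound 4.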

Compound 4, half-maximal inhibitory concentration: > 50000 nM
Compound 4: only a limit was reported (the forecaster's own chance of this, stated with the estimate: 85%); the middle value lies beyond the limit too.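

In this assay, within the data shown here, compound 4 gives > 50000 nM, a limit, so no step to it from compound 1, compound 2 or compound 3 can be read in size: the limit of > 50000 nM in this assay, at which 4 of the 4 values shown sit.

The compounds shown leave open whether any change to the alkenyl chain or the shared core would give a readable value in this assay at all.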